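Moving the Chain Nitrogen One Bond Along

The source may report more compounds than this note shows. Statements on the series, on what has been measured and on what is new or still open speak of the compounds shown alone.

Compound 1, `CCCCCCCCCCc1ccc(-c2noc(C3CNC3)n2)cc1`: 65%
Compound 2, `CCCCCCCCCCc1ccc(-c2noc(CCCCN)n2)cc1`: 55%

In an assay on HeLa cells for inhibition of sphingosine-1-phosphate transporter SPNS2 (Mus musculus), read by LC-MS, tested at 2 uM (on this read-out lower numbers stand for less inhibition and higher numbers for more inhibition at the one concentration tested (going by the name of the read-out)), compound 1 gives 65% and compound 2 gives 55%. Compound 2 has the smaller of the two numbers, but a number 10 percentage points lower from compound 1 to compound 2 (within the scatter) lies within the scatter, so the two read alike. Compound 3, `CCCCCCCCCCc1ccc(-c2noc(CCCNC)n2)cc1`, differs from compound 2 by methylamino in place of aminomethyl on a saturated chain carbon, three bonds along the chain from an aromatic carbon. Going by the values given here, no measured step moves a nitrogen along a chain in this way; the only step measured swapped azetidin-3-yl for 4-aminobutyl without leaving the scatter. No step beyond the scatter is therefore expected for compound 3, estimated as no change at the digits printed from compound 2 to compound 3 (within the scatter). Compound 3 is expected at 55%, between 35% and 75%.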

Compound 3, a percentage reported as inhibition, at one concentration (the size of the read-out at that concentration, not a potency): 45%
Compound 3: the middle estimate sits 10 percentage points above what was measured; measured number inside the range.
By their numbers in this assay, from the lowest: compounds 3, 2 and 1 (each within the scatter of the next, the first and the last beyond it).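

Moving the nitrogen one bond along the chain in this assay gives a number 10 percentage points lower from compound 2 to compound 3 (within the scatter) and so, on its own, this change makes no clear difference at this position. Going by these compounds alone, putting 3-(methylamino)propyl in place of azetidin-3-yl gives a number 20 percentage points lower from compound 1 to compound 3 (beyond the scatter) and is the first step in this set to clear the scatter, though only modestly. Nothing measured here explains either step.

The compounds shown leave open how a 3-(dimethylamino)propyl group or a carboxylic acid at the end of the chain would read. From the compounds shown here alone, how a longer chain carrying the amine would compare also remains open.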